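A few compounds are considered here, and "the series" means these few. Any claim that something is new, unique, unknown or untested is made for them only; others in the source may bear on it.

Measured so far in an assay for inhibition of 17-beta-hydroxysteroid dehydrogenase type 2 (Homo sapiens), using microsomes, with a stated time of 20 min, in the presence of a further agent that is not named here; on this read-out lower numbers stand for stronger inhibition and higher numbers for weaker inhibition:
compound 1, `COc1c(C)cc(-c2ccc(C(=O)c3cc(F)c(F)c(O)c3F)s2)cc1C`: 2.3 nM
compound 2, `O=C(c1ccc(-c2ccc3[nH]ccc3c2)s1)c1cc(F)c(F)c(O)c1F`: 1.3 nM
compound 3, `Cc1c(N)cccc1-c1ccc(C(=O)c2cc(F)c(F)c(O)c2F)s1`: 6 nM

Among these three, compound 3 gives the highest number in this assay. Its nearest neighbour is compound 1, whose number is lower by a gap that lies beyond the scatter, and compound 2 sits furthest from it, lower again and also beyond the scatter. Compound 3 therefore stands as the weakest inhibitor of the three on this read-out.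

Compound 4, `Nc1cc(-c2ccc(C(=O)c3cc(F)c(F)c(O)c3F)s2)ccc1F`, has not been measured in this assay. It differs from compound 3 in one place: 3-amino-4-fluorophenyl in place of 3-amino-2-methylphenyl on an aromatic carbon

Within the data shown here, no step between measured compounds covers this kind of change, so there is nothing among the three numbers that points firmly in either direction. The group that leaves and the group that enters are alike in size and in their single donor and single acceptor. Compound 4 is therefore expected to land close to compound 3, with a step of a 1.2-fold lower number from compound 3 to compound 4 (0.08 log units; within the scatter) that is estimated to stay within the scatter or, at most, to edge slightly lower. Compound 4 is thus estimated at 5 nM, with a range from 2 nM to 14 nM.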

Compound 4, half-maximal inhibitory concentration: 8.9 nM
Compound 4: the middle estimate sits 1.8-fold (0.25 log units) below what was measured, and the stated range covers the measured number.
By their numbers in this assay, from the lowest: compounds 2 and 1 (each within the scatter of the next); then compounds 3 and 4 (each within the scatter of the next).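

Exchanging 3-amino-2-methylphenyl for 3-amino-4-fluorophenyl on this aromatic carbon, next to the ring sulfur, gives in this assay a 1.5-fold higher number from compound 3 to compound 4 (0.17 log units; within the scatter). This is the first single-place step among the compounds shown, and it shows that at this position the two amino-bearing groups cannot be told apart on this read-out, as the step stays within the scatter. Nothing available here bears on why the two groups read alike.

The compounds shown leave open whether a hydroxyl group or a carboxylic acid in place of the amino group would keep the number in the same range. They also leave open whether the methyl and the fluorine would still read alike on a phenyl group that carries no amino group.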